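Aryl swap on the benzylamine arm: outlook for compound 3

The source may report more compounds than this note shows. Statements on the series, on what has been measured and on what is new or still open speak of the compounds shown alone.

Compound 1 `OC[C@H]1O[C@@H](n2cnc3c(NCc4cccc(Br)c4)ncnc32)[C@H](O)[C@@H]1O` is the reference point. In a functional assay on CCRF-CEM cells (Homo sapiens) for antiproliferative activity, with a stated time of 72 h (on this read-out lower numbers stand for stronger inhibition and higher numbers for weaker inhibition), compound 1 gives 5000 nM, and this is the only number shown for the series. Compound 2 `COc1ccc(CNc2ncnc3c2ncn3[C@@H]2O[C@H](CO)[C@@H](O)[C@H]2O)c(OC)c1` reaches in this assay only the assay limit of > 166000 nM, not a number. Among the compounds with values here, the single measured step, an at least 33-fold higher number from compound 1 to compound 2 (1.52 log units; beyond the scatter), therefore runs into the limit of > 166000 nM in this assay, at which 1 of the 2 values shown sits, and its true size is known only as a minimum.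

Compound 3 `OC[C@H]1O[C@@H](n2cnc3c(NCc4c(F)ccc(F)c4F)ncnc32)[C@H](O)[C@@H]1O` differs from compound 1 by 2,3,6-trifluorophenyl in place of 3-bromophenyl on a saturated chain carbon bound to a nitrogen on an aromatic ring. Within the data shown here, the step from compound 1 to compound 2 is the only comparison that bears on this change; it is large and shows that exchanging the aryl group on that chain carbon can remove measurable activity altogether. Among the measured compounds shown here, compound 3 brings in fluorines rather than methoxy groups, and no measured pair covers that kind of exchange. For compound 3 the expected step is a 2.4-fold higher number from compound 1 to compound 3 (0.38 log units; beyond the scatter), an expected weakening beyond the scatter that should be smaller than the measured step. Compound 3 is estimated at 12000 nM, within a range from 2500 nM to 80000 nM.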

Compound 3, half-maximal inhibitory concentration: 90300 nM
Estimate against measurement, compound 3: 7.5-fold (0.88 log units) below, outside the stated range (above it).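

The second aryl exchange at this position is also costly: in this assay, 2,3,6-trifluorophenyl in place of 3-bromophenyl on the saturated chain carbon gives an 18-fold higher number from compound 1 to compound 3 (1.26 log units; beyond the scatter). The large loss is therefore not confined to the 2,4-dimethoxyphenyl of compound 2, since it also appears with a fluorinated aryl group, although compound 3 still gives a measured number; among the three compounds, both exchanges weaken the read-out, none goes against this, and compound 1 remains the strongest. The two replacements can be separated only loosely, with an at least 1.8-fold lower number from compound 2 to compound 3 (0.26 log units; that floor lies within the scatter), and the true gap stays unknown because the value for compound 2 is an assay limit: the limit of > 166000 nM in this assay, at which 1 of the 3 values shown sits.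

The compounds shown leave open whether a plain phenyl, a 3-chlorophenyl or a 3-methoxyphenyl group on the same chain carbon would keep the activity of compound 1 or lose it as well. They also leave open whether the bromine or the rest of the aryl group carries that activity, and whether a pyridine ring could replace the benzene ring.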